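Swapping one halogen on a benzylic sulfone series

The compounds below may be only part of what the source reports. "The series", "measured", "known", "first", "only" and "open" are said of these compounds alone.

Of the compounds shown here, three sharing one core have been measured in a functional assay on RAW264.7 cells (Mus musculus), read by fluorescence; a lower number here means a stronger inhibitor, a higher number a weaker inhibitor. Compound 3 `CCOC(=O)C1=CCCCC1S(=O)(=O)Cc1ccc(Cl)cc1Cl` gives 60 nM. Compound 1 `CCOC(=O)C1=CCCCC1S(=O)(=O)Cc1ccc(Cl)cc1F` gives 104 nM. Compound 2 `CCOC(=O)C1=CCCCC1S(=O)(=O)Cc1cccc(Cl)c1Cl` gives 65 nM. Compound 2 and compound 3 have the same atoms joined differently, and the difference between their cores is not broken down here.

From compound 3 to compound 1 the change is fluoro in place of chloro on an aromatic carbon, and it made a 1.7-fold higher number from compound 3 to compound 1 (0.24 log units; within the scatter). Compound 4 `CCOC(=O)C1=CCCCC1S(=O)(=O)Cc1cccc(Cl)c1F` is not yet measured; from compound 2 to compound 4 the change is fluoro in place of chloro on an aromatic carbon. This is the same kind of change, but at a place that is ortho to a chloro group rather than meta to one. Because the earlier step was a 1.7-fold higher number from compound 3 to compound 1 (0.24 log units; within the scatter), a similar step is expected here, a 1.5-fold higher number from compound 2 to compound 4 (0.19 log units; within the scatter). Compound 4 is therefore estimated at 100 nM, likely between 45 nM and 220 nM.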

Compound 4, half-maximal inhibitory concentration: 12 nM
Beside the measured number, compound 4's estimate is 8.3-fold (0.92 log units) above it; measured number outside the range, below it.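

Fluoro in place of chloro made a 5.4-fold lower number from compound 2 to compound 4 (0.73 log units; beyond the scatter), so here the swap gave a clearly stronger inhibitor. In this assay, the effect of this one swap was not the same on the two cores, so the step from one pair did not carry over to the other: the same change on two cores in this assay, a 1.7-fold higher number (0.24 log units; within the scatter) from compound 3 to compound 1 and a 5.4-fold lower number (0.73 log units; beyond the scatter) from compound 2 to compound 4, 9.4-fold (0.97 log units) apart, beyond the scatter of two such steps

This shows that the outcome depends on the surrounding structure, but two pairs cannot show which feature of it is responsible or how the swap would behave on any further core. The compounds shown leave open whether a methyl or methoxy group on the same carbon would match fluoro in compound 4. They also leave open whether that strength would survive replacing the ethyl ester with a carboxylic acid or an amide.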